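Trading a fluoro for a chloro on compound 2

The source may report more compounds than this note shows. Statements on the series, on what has been measured and on what is new or still open speak of the compounds shown alone.

Clearance tells how quickly the body removes a compound from the blood. In an ADME assay on the whole organism (Rattus norvegicus, strain Sprague-Dawley) for pharmacokinetics, using cassette dosing, at a dose of 0.5 mg/kg by the intravenous route (on this read-out lower numbers stand for slow clearance and higher numbers for fast clearance), compound 2 `C[C@@H]1CN(c2ccc(F)c(F)c2)CCN1C(=O)C(=O)Nc1ccc2[nH]c(=O)oc2c1` gives 5.6 mL/min/kg and stands level with compound 1 `O=C(Nc1ccc2[nH]c(=O)oc2c1)C(=O)N1CCN(c2ccc(Cl)c(F)c2)CC1` which gives 5.6 mL/min/kg at the digits shown.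

The next compound, compound 3 `C[C@@H]1CN(c2ccc(Cl)c(F)c2)CCN1C(=O)C(=O)Nc1ccc2[nH]c(=O)oc2c1`, changes a single place on compound 2: chloro in place of fluoro on an aromatic carbon with chloro in place of fluoro on an aromatic carbon, ortho to a fluoro group and para to a large group. The 3,4-difluorophenyl thus becomes 4-chloro-3-fluorophenyl.

Among the measured compounds shown here, no two measured compounds differ in just one place, so the data hold no direct measure of this swap. The only hint is weak: compound 1 already carries the 4-chloro-3-fluorophenyl group and gives 5.6 mL/min/kg in this assay, the same reading as compound 2. No shift beyond the usual scatter is therefore expected. The estimated change is a 1.0-fold lower number from compound 2 to compound 3 (0.01 log units; within the scatter) and it should stay within that scatter. For compound 3 the expected clearance is 5.5 mL/min/kg with an estimated range from 2.8 mL/min/kg to 11 mL/min/kg.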

Compound 3, clearance: 1.37 mL/min/kg
Compound 3: middle estimate off by 4.0-fold (0.60 log units), on the high side; measured number below the stated range.
By their numbers in this assay, from the lowest: compound 3; then compounds 1 and 2 (each within the scatter of the next).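

In this assay, chloro in place of fluoro on this aromatic carbon, para to a large group, proves to be a real change and gives a 4.1-fold lower number from compound 2 to compound 3 (0.61 log units; beyond the scatter). Compound 3 also opens a second comparison on a different part of the molecule, where methyl in place of hydrogen on a saturated ring carbon gives a 4.1-fold lower number from compound 1 to compound 3 (0.61 log units; beyond the scatter). Compounds 1 and 2 differ in two places and could not separate these changes, whereas compound 3 shows that each one lowers clearance when the other is already present. The data at hand offer no measured explanation for either step.

From the compounds shown here alone, each step has been read only once, so it remains open whether the chloro step would hold on a compound without the methyl, and whether the methyl step would hold on a compound carrying the 3,4-difluorophenyl group. Going by these compounds, it is also open how clearance would respond to a bromo, a trifluoromethyl or a nitrile at the same aromatic carbon, or to an ethyl in place of the methyl on the saturated ring carbon.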